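Replacing the acetyl group of compound 2

The source may hold more compounds than are shown below. What is called first, only, known or untested is meant among the compounds shown, and "the series" means these compounds.

Measured in a functional assay on HeLa cells (Homo sapiens) for inhibition; a higher number here means a weaker inhibitor, a lower number a stronger inhibitor:
Compound 1 `Cc1cn(/C=C/C#N)c(=O)[nH]c1=O`: > 100000 nM (a limit)
Compound 2 `CC(=O)/C=C/n1cc(C)c(=O)[nH]c1=O`: > 100000 nM (a limit)

Compound 2 stands at > 100000 nM in this assay, which is a limit of the assay and not a number. Compound 1 also gives only a limit. Compound 3 `Cc1cn(/C=C/C=N/O)c(=O)[nH]c1=O` has not yet been measured. It differs from compound 2 on a double-bonded chain carbon bound to a double-bonded chain carbon: a group of 3 heavy atoms (1 carbon, 1 nitrogen, 1 oxygen; no ring) in place of a group of 3 heavy atoms (2 carbon, 1 oxygen; no ring), on a double-bonded chain carbon bound to a double-bonded chain carbon. For the measured compounds named here, one measured step bears on this change, with acetyl in place of cyano at that same place: a step that the two limits leave unreadable from compound 1 to compound 2. Its size cannot be read, and both compounds sit at one limit (the limit of > 100000 nM in this assay, at which 2 of the 2 values shown sit). No step beyond the scatter is therefore expected, and the estimated step is a number no higher from compound 2 to compound 3 (the limit leaves the size open), though with little to support it. For compound 3 the expected value is 100000 nM, with an estimated range from 30000 nM to 300000 nM (this may again be reported only as a limit).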

Compound 3, half-maximal inhibitory concentration: > 100000 nM
Compound 3 gave a limit, no number; the forecaster's own chance of this, stated with the estimate: 75%; the middle value lies on the limit itself.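

In this assay compound 3 gives > 100000 nM as a limit and not a number. The steps among compound 1, compound 2 and compound 3 therefore cannot be read. The compounds shown leave open how strongly each inhibits, and whether these groups differ at all.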